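The source may report more compounds than this note shows. Statements on the series, on what has been measured and on what is new or still open speak of the compounds shown alone.

Measured compounds:
- compound 1 `O=C(COc1ccc2cc(/C=C3/SC(=O)NC3=O)ccc2c1)Nc1cccc(Cl)c1` gives 3800 nM in an assay on isolated protein for inhibition of histone deacetylase 4 (Homo sapiens), with a stated time of 1 h; on this read-out higher numbers stand for weaker inhibition and lower numbers for stronger inhibition
- compound 2 `O=C(COc1ccc2cc(/C=C3/SC(=O)NC3=O)ccc2c1)Nc1ccccn1` gives 17000 nM in this assay

Compound 1 stands as the lower of the two numbers; its nearest neighbour is compound 2, and the step of a 4.5-fold higher number from compound 1 to compound 2 (0.65 log units; beyond the scatter) lies beyond the scatter, so compound 1 is the stronger inhibitor of the pair.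

Compound 3 `O=C(COc1ccc2cc(/C=C3/SC(=O)NC3=O)ccc2c1)Nc1ccc(Br)c(Br)c1` has not been measured. It differs from compound 1 in one place: 3,4-dibromophenyl in place of 3-chlorophenyl on an amide-type nitrogen

Among the compounds with values here, only one measured step is available, a 4.5-fold higher number from compound 1 to compound 2 (0.65 log units; beyond the scatter), and it concerns a different change, an aromatic ring carrying a nitrogen in place of a halogen-bearing phenyl. It shows that the halogenated phenyl of compound 1 is the better of the two groups tried on the amide-type nitrogen, but it says nothing direct about adding a second halogen or moving from chlorine to bromine. Within the data shown here, with no step of the same kind, the change from compound 1 to compound 3 is expected to stay within or near the scatter, with a slight lean toward a lower number, a 1.5-fold lower number from compound 1 to compound 3 (0.18 log units; within the scatter). Compound 3 is therefore estimated at 2500 nM, within a range from 800 nM to 8000 nM in this assay.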

Compound 3, half-maximal inhibitory concentration: 4900 nM
For compound 3 the middle estimate is 2.0-fold (0.29 log units) below the measured one; low and high end bracket the measured number.
By their numbers in this assay, from the lowest: compounds 1 and 3 (each within the scatter of the next); then compound 2.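

In this assay, the step to 3,4-dibromophenyl on the amide-type nitrogen reads a 1.3-fold higher number from compound 1 to compound 3 (0.11 log units; within the scatter) and so cannot be told apart from repeat-measurement scatter, which means this position tolerates a larger group carrying two bromine atoms in place of one chlorine without a detectable shift. The comparison with the ring containing nitrogen reads a 3.5-fold lower number from compound 2 to compound 3 (0.54 log units; beyond the scatter) and lies beyond the scatter, so the advantage over pyridin-2-yl is now seen with two different halogen-bearing phenyl groups rather than with 3-chlorophenyl alone, and neither of the three compounds goes against this. No measurement shown gives a reason for either step.

Because the number of halogens and their identity change together in this swap, the two changes cannot be separated here, and 3-bromophenyl or 3,4-dichlorophenyl would be the groups to pull them apart. Also open, going by these compounds, is how the same phenyl ring behaves with no halogen at all, or with a methoxy group, an amine or a carboxylic acid in its place.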